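Trifluoromethyl in place of trifluoromethoxy: a one-group swap

This account rests on a few compounds, and the source may have more. Where it says the series, first, only, none or still open, it means among the compounds named here.

Measured compounds:
- Compound 1 `O=C(Nc1ccc(C(F)(F)F)cc1)c1cc(Cl)ccc1O` gives 710 nM
- Compound 2 `O=C(Nc1ccc(OC(F)(F)F)c(Cl)c1)c1cc(Cl)ccc1O` gives 840 nM

Both values come from a functional assay on Jurkat cells (Homo sapiens) for cytotoxicity, read by luminescence and CellTiter-Glo, with a stated time of 3 days (a lower number here means a stronger inhibitor, a higher number a weaker inhibitor), and they lie within the usual scatter of each other, so compound 2 cannot be told apart from compound 1 on these numbers.

Compound 3 `O=C(Nc1ccc(C(F)(F)F)c(Cl)c1)c1cc(Cl)ccc1O` has not yet been measured. It differs from compound 2 by one group, with trifluoromethyl in place of trifluoromethoxy on an aromatic carbon.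

Going by the values given here, no measured pair shows this exact swap, so the expectation is indirect. Compound 1 (710 nM) already carries trifluoromethyl and sits within the scatter of compound 2 (840 nM). The expected step of a 1.3-fold lower number from compound 2 to compound 3 (0.11 log units; within the scatter) is therefore none beyond the scatter. Among the compounds with values here, compound 3 is estimated at 650 nM in this assay with an expected range from 250 nM to 1700 nM (a wide range, as only two values support it).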

Compound 3, half-maximal inhibitory concentration: 690 nM
Compound 3: middle estimate off by 1.1-fold (0.03 log units), on the low side; low and high end bracket the measured number.
By their numbers in this assay, from the lowest: compounds 3, 1 and 2 (each within the scatter of the next).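

In this assay, the swap now has a direct pair: a 1.2-fold lower number from compound 2 to compound 3 (0.09 log units; within the scatter). At this position, then, trifluoromethyl and trifluoromethoxy cannot be told apart, even though the swap removes the oxygen that links the group to the aromatic carbon. Going by these compounds alone, the chloro change can also be read directly for the first time, and with trifluoromethyl in place it too cannot be told apart from hydrogen: a 1.0-fold lower number from compound 1 to compound 3 (0.01 log units; within the scatter). No measurement shown here offers an explanation for either result. As far as these compounds go, whether an amine, a carboxylic acid or a longer chain at the trifluoromethyl position would move the number beyond the scatter remains open. Also open, from the compounds shown here alone, is what a methoxy group in place of the hydroxyl, which all three compounds share, would do in this assay.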